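From cyclopropyl to butyl on a carbonyl carbon

The source may hold more compounds than are shown below. What is called first, only, known or untested is meant among the compounds shown, and "the series" means these compounds.

Of the compounds shown here, two sharing one core have numbers so far. In a physicochemical assay for metabolic stability, read by spectrophotometry, in phosphate buffer, at 25 degrees C, at pH 7.3 (a lower number here means that the compound disappears faster, a higher number that the compound lasts longer), compound 1 `Cc1cccc(C(=O)n2cc(C#N)c3cccnc32)c1` gives 1.9 h as its half-life, while compound 2 `N#Cc1cn(C(=O)C2CC2)c2ncccc12` gives 6.8 h as its half-life. Compound 2 therefore holds the higher of the two numbers, and its gap to compound 1 lies beyond the usual scatter. Compound 3 `CCCCC(=O)n1cc(C#N)c2cccnc21` carries butyl in place of cyclopropyl on a carbonyl carbon, a difference counted as butyl in place of cyclopropyl on a carbonyl carbon in full. Within the data shown here, no measured pair differs in one place only, so the data offer no direct precedent for this change. Since compound 2 at 6.8 h stands highest of just two numbers, a moderate fall in this assay is expected rather than a rise. The expected change is a 2.4-fold lower number from compound 2 to compound 3 (0.39 log units; beyond the scatter) and would lie slightly beyond the scatter. Compound 3 is estimated to show 2.8 h as its half-life, within a range from 1.2 h to 6.5 h on repeated measurement.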

Compound 3, half-life: 1.9 h
Beside the measured number, compound 3's estimate is 1.5-fold (0.17 log units) above it; the range from low to high includes it.
By their numbers in this assay, from the lowest: compounds 1 and 3 (each within the scatter of the next); then compound 2.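

Butyl in place of cyclopropyl on a carbonyl carbon gives a 3.6-fold lower number from compound 2 to compound 3 (0.55 log units; beyond the scatter) in this assay, the first reading of a change in one place at this position, and it shows that the number responds to the group held there. Compound 3 gives 1.9 h and compound 1 gives 1.9 h, two values within the scatter of each other, so among the three compounds only compound 2, with cyclopropyl, stands apart. Nothing available explains this step.

The compounds shown leave open whether the higher number of compound 2 goes with the closed ring or with the smaller count of carbon atoms. A cyclobutyl group or an open propyl chain at the same place would separate these two readings, and an amine there would test a group of another kind.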